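The source may report more compounds than this note shows. Statements on the series, on what has been measured and on what is new or still open speak of the compounds shown alone.

In a functional assay on NCI/ADR cells (Homo sapiens) for inhibition, read by sulforhodamine B assay, with a stated time of 48 h (a higher number here means a weaker inhibitor of growth, a lower number a stronger inhibitor of growth), compound 1 `COc1cc(/C=C/C2CC=CC(=O)O2)cc(OC)c1` gives 8.9 uM. Compound 2 `COc1cc(/C=C/C2CC=CC(=O)O2)cc(OC)c1OC` carries one more methoxy group, and in this assay compound 2 gives 35.1 uM. That change, (methoxy in place of hydrogen on an aromatic carbon), produced a 3.9-fold higher number from compound 1 to compound 2 (0.60 log units; beyond the scatter). Compound 3 `COc1ccc(/C=C/C2CC=CC(=O)N2)cc1OC` rests on a different core; how the two cores differ is not broken down here. In this assay compound 3 reaches only a limit of the assay, > 964 uM, which is the limit of > 964 uM in this assay, at which 1 of the 3 values shown sits. Compound 4 `COc1cc(OC)c(OC)cc1/C=C/C1CC=CC(=O)N1` arises from compound 3 by the same kind of change, (methoxy in place of hydrogen on an aromatic carbon), though here the entering methoxy sits ortho to a group of 9 heavy atoms, meta to a methoxy group and para to a methoxy group, whereas in compound 2 it sits ortho to two methoxy groups and para to a group of 9 heavy atoms. Because the earlier change gave a 3.9-fold higher number from compound 1 to compound 2 (0.60 log units; beyond the scatter), the step is expected to be a step that the limit leaves unreadable from compound 3 to compound 4. Compound 4 is thus estimated at 1500 uM, most likely again reported only as a limit of the assay.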

Compound 4, concentration for growth inhibition (reported as GI): > 864 uM
Compound 4 gave a limit, no number; the forecaster's own chance of this, stated with the estimate: 85%; the middle value does not contradict the limit.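

Compound 3 and compound 4 both reach only a limit of the assay, so the step between them cannot be read. The compounds shown leave open whether this added methoxy changes growth inhibition on the core of compound 3.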